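This account rests on a few compounds, and the source may have more. Where it says the series, first, only, none or still open, it means among the compounds named here.

Compound 1 `Cc1ccc(NC(=O)NC(=O)c2ccc(OCc3ccc(C(F)(F)F)cc3)cc2)cc1-c1nc2ccccc2[nH]1`: 7830 nM
Compound 2 `Cc1ccc(NC(=O)NC(=O)c2ccc(OCc3cccc(Cl)c3Cl)cc2)cc1-c1nc2ccccc2[nH]1`: 48500 nM
Compound 3 `Cc1ccc(COc2ccc(C(=O)NC(=O)Nc3ccc(C)c(-c4nc5ccccc5[nH]4)c3)cc2)cc1`: 5110 nM

In a functional assay on HT-29 cells (Homo sapiens) for inhibition, read by MTT assay, with a stated time of 48 h (on this read-out lower numbers stand for stronger inhibition and higher numbers for weaker inhibition), compound 3 stands lowest of the three numbers. The step of a 1.5-fold lower number from compound 1 to compound 3 (0.19 log units; within the scatter) lies within the scatter, whereas a 9.5-fold lower number from compound 2 to compound 3 (0.98 log units; beyond the scatter) and a 6.2-fold higher number from compound 1 to compound 2 (0.79 log units; beyond the scatter) lie beyond it.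

Compound 4 `Cc1ccc(NC(=O)NC(=O)c2ccc(OCc3ccc(F)cc3)cc2)cc1-c1nc2ccccc2[nH]1` differs from compound 3 by fluoro in place of methyl on an aromatic carbon. The step that bears most directly on this change is a 1.5-fold lower number from compound 1 to compound 3 (0.19 log units; within the scatter), where a different substituent at the same aromatic carbon left the number within the scatter; the two steps involving compound 2 alter the substitution pattern of the ring and bear less. The writer therefore expects no step beyond the scatter. Compound 4 is expected to give 6500 nM, between 2500 nM and 17000 nM. The step of a 1.3-fold higher number from compound 3 to compound 4 (0.10 log units; within the scatter) is expected to stay within the scatter.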

Compound 4, half-maximal inhibitory concentration: 980 nM
Beside the measured number, compound 4's estimate is 6.6-fold (0.82 log units) above it; the measured number lies below the stated range.
By their numbers in this assay, from the lowest: compound 4; then compounds 3 and 1 (each within the scatter of the next); then compound 2.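

In this assay, the aromatic carbon para to a large group proves sensitive to its substituent: methyl and trifluoromethyl had left the number within the scatter, yet fluoro separates from both, with a 5.2-fold lower number from compound 3 to compound 4 (0.72 log units; beyond the scatter) and an 8.0-fold lower number from compound 1 to compound 4 (0.90 log units; beyond the scatter). The 4-fluorobenzyl group also widens the span of the series, with a 49-fold lower number from compound 2 to compound 4 (1.69 log units; beyond the scatter). Nothing available here accounts for this result. From the compounds shown here alone, whether the gain is specific to fluoro remains open, and a chloro, a methoxy or a nitrile on this same carbon would test it.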